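This account rests on a few compounds, and the source may have more. Where it says the series, first, only, none or still open, it means among the compounds named here.

Measured compounds in a functional assay on HT-29 cells (Homo sapiens) for cytotoxicity, read by MTT assay, with a stated time of 72 h; a higher number here means a weaker inhibitor, a lower number a stronger inhibitor:
Compound 1 `COc1ccc(/C=C2\S/C(=N\c3csc(-c4ccc(Cl)cc4)c3)NC2=O)cc1`: compound 1 gives 3800 nM
Compound 2 `CN(C)c1ccc(/C=C2\S/C(=N\c3csc(-c4ccc(Cl)cc4)c3)NC2=O)cc1`: compound 2 gives 1500 nM
Compound 3 `O=C1N/C(=N/c2csc(-c3ccc(Cl)cc3)c2)S/C1=C\c1ccc2ccccc2c1`: compound 3 gives 3700 nM

Among these three numbers compound 3 holds the second highest. Its nearest neighbour is compound 1, and that step is within the scatter: a 1.0-fold lower number from compound 1 to compound 3 (0.01 log units; within the scatter). Its furthest is compound 2; there the step is a 2.5-fold higher number from compound 2 to compound 3 (0.39 log units; beyond the scatter), a modest rise from the lowest number of the set.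

Compound 4 `O=C1N/C(=N/c2csc(-c3ccc(Cl)cc3)c2)S/C1=C\c1ccc(F)cc1` differs from compound 3 at the arylidene position: 4-fluorophenyl in place of naphthalen-2-yl on a double-bonded chain carbon bound to a double-bonded ring carbon. Among the compounds with values here, two measured steps touch the same place. The exchange of 4-methoxyphenyl for naphthalen-2-yl gave a 1.0-fold lower number from compound 1 to compound 3 (0.01 log units; within the scatter), while the exchange of 4-(dimethylamino)phenyl for naphthalen-2-yl gave a 2.5-fold higher number from compound 2 to compound 3 (0.39 log units; beyond the scatter). Within the data shown here, neither step involved a 4-fluorophenyl group, so no direct precedent exists for the new group; the only modest movement at this position came with the dimethylamino group of compound 2, which compound 4 does not carry. Compound 4 is therefore expected to sit close to compound 3, with at most a small shift and none that clearly exceeds the scatter: a 1.2-fold higher number from compound 3 to compound 4 (0.09 log units; within the scatter). The estimate for compound 4 in this assay is 4500 nM, in a range from 1800 nM to 11000 nM.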

Compound 4, half-maximal inhibitory concentration: 4100 nM
Compound 4: middle estimate off by 1.1-fold (0.04 log units), on the high side; low and high end bracket the measured number.
By their numbers in this assay, from the lowest: compound 2; then compounds 3, 1 and 4 (each within the scatter of the next).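

In this assay the place on a double-bonded chain carbon bound to a double-bonded ring carbon tolerated the loss of one of the two aromatic rings of naphthalen-2-yl, since 4-fluorophenyl in its place gave a 1.1-fold higher number from compound 3 to compound 4 (0.04 log units; within the scatter) and left compound 4 level with compound 3. Fluoro in place of methoxy on an aromatic carbon likewise gave a 1.1-fold higher number from compound 1 to compound 4 (0.03 log units; within the scatter), so three different groups at this position now sit together, and the exchange of a two-ring group for a one-ring group is seen to matter as little as the earlier exchange with 4-methoxyphenyl. Fluoro in place of dimethylamino gave a 2.7-fold higher number from compound 2 to compound 4 (0.44 log units; beyond the scatter), which leaves compound 2 as the only one of the four set apart from the others, and nothing measured here accounts for that gap.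

The compounds shown leave open whether the lower number of compound 2 belongs to dimethylamino alone or would also appear with another amine, such as a morpholine or a free amino group, on the same aromatic carbon. They also leave open whether a carboxylic acid there would move the number at all.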